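This account rests on a few compounds, and the source may have more. Where it says the series, first, only, none or still open, it means among the compounds named here.

- compound 1 `COc1ccc(S(=O)(=O)N2CCc3cccc(-c4ccc(F)nc4)c32)cc1` gives 135 nM
- compound 2 `COc1ccc(-c2cccc3c2N(S(=O)(=O)c2ccc(OC)cc2)CC3)cc1` gives 302 nM

In a functional assay on NCI-H460 cells (Homo sapiens) for inhibition, with a stated time of 72 h (on this read-out lower numbers stand for stronger inhibition and higher numbers for weaker inhibition), compound 2 has the higher of the two numbers, which makes it the weaker inhibitor of the pair. Compound 3 `COc1ccc(S(=O)(=O)N2CCc3cccc(-c4ccncc4)c32)cc1` has pyridin-4-yl in place of 4-methoxyphenyl on an aromatic carbon and is otherwise the same. For the measured compounds named here, the only measured step at this place is a 2.2-fold higher number from compound 1 to compound 2 (0.35 log units; beyond the scatter) and it is modest. It links 4-methoxyphenyl to 6-fluoropyridin-3-yl, the pyridine group of compound 1. A similar modest step to a lower number is therefore expected, namely a 1.9-fold lower number from compound 2 to compound 3 (0.28 log units; within the scatter) as an estimate. Compound 3 is estimated at 160 nM with an expected range from 60 nM to 420 nM and no tighter claim is possible from two measurements.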

Compound 3, half-maximal inhibitory concentration: 101 nM
Estimate against measurement, compound 3: 1.6-fold (0.20 log units) above, and the stated range covers the measured number.
By their numbers in this assay, from the lowest: compounds 3 and 1 (each within the scatter of the next); then compound 2.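

Pyridin-4-yl in place of 4-methoxyphenyl gives a 3.0-fold lower number from compound 2 to compound 3 (0.48 log units; beyond the scatter) in this assay, so a second pyridine group also sits on the stronger side of the methoxy-bearing ring. With a 1.3-fold lower number from compound 1 to compound 3 (0.13 log units; within the scatter) as the step between the two pyridine groups, they cannot be told apart here, and the fluorine of compound 1 is not needed to keep that advantage. No measured evidence explains the difference from 4-methoxyphenyl.

Still open, on these data alone, is whether an unsubstituted phenyl would behave like the pyridine groups, and how a ring carrying an amine or a carboxylic acid would fare on this aromatic carbon.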